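Sulfonamide Heteroaryl Swaps on a Shared Terpenoid Core

The source may hold more compounds than are shown below. What is called first, only, known or untested is meant among the compounds shown, and "the series" means these compounds.

Measured compounds:
- Compound 1, `C=C1CC[C@@H]2[C@](C)(COC(C)=O)[C@H](OC(C)=O)CC[C@@]2(C)[C@H]1CC(Nc1ccc(S(=O)(=O)Nc2ccc(Cl)nn2)cc1)C1=CCOC1=O`, gives 1910 nM in a functional assay on SNB-19 cells (Homo sapiens) for inhibition, read by sulforhodamine B assay, with a stated time of 48 h; a lower number here means a stronger inhibitor of growth, a higher number a weaker inhibitor of growth.
- Compound 2, `C=C1CC[C@@H]2[C@](C)(COC(C)=O)[C@H](OC(C)=O)CC[C@@]2(C)[C@H]1CC(Nc1ccc(S(=O)(=O)Nc2cc(C)on2)cc1)C1=CCOC1=O`, gives 3120 nM in this assay.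
- Compound 3, `C=C1CC[C@@H]2[C@](C)(COC(C)=O)[C@H](OC(C)=O)CC[C@@]2(C)[C@H]1CC(Nc1ccc(S(=O)(=O)Nc2ncccn2)cc1)C1=CCOC1=O`, gives 1630 nM in this assay.

The three measured compounds share one core and differ only in the aromatic ring on the sulfonamide nitrogen. Compound 1 stands in the middle of the three numbers, yet every gap around it lies within the scatter: a 1.6-fold higher number from compound 1 to compound 2 (0.21 log units; within the scatter) and a 1.2-fold lower number from compound 1 to compound 3 (0.07 log units; within the scatter), and likewise a 1.9-fold lower number from compound 2 to compound 3 (0.28 log units; within the scatter). Exchanging one small aromatic ring for another at this position has so far produced no step beyond the scatter.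

Compound 4, `C=C1CC[C@@H]2[C@](C)(COC(C)=O)[C@H](OC(C)=O)CC[C@@]2(C)[C@H]1CC(Nc1ccc(S(=O)(=O)Nc2nccs2)cc1)C1=CCOC1=O`, carries the same kind of change: 1,3-thiazol-2-yl in place of 6-chloropyridazin-3-yl on a sulfonamide nitrogen. Because the earlier ring swaps gave a 1.6-fold higher number from compound 1 to compound 2 (0.21 log units; within the scatter) and a 1.2-fold lower number from compound 1 to compound 3 (0.07 log units; within the scatter), no step beyond the scatter is expected in this assay for compound 4 either, so the estimated step is a 1.0-fold higher number from compound 1 to compound 4 (0.02 log units; within the scatter). Compound 4 is therefore expected to give about 2000 nM, with a likely range from 900 nM to 4500 nM.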

Compound 4, concentration for 50% growth inhibition: 4360 nM
Estimate against measurement, compound 4: 2.2-fold (0.34 log units) below, and the stated range covers the measured number.
By their numbers in this assay, from the lowest: compounds 3, 1, 2 and 4 (each within the scatter of the next, the first and the last beyond it).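

The ring swap on the sulfonamide nitrogen now gives its first steps beyond the scatter in this assay, both modest and both with 1,3-thiazol-2-yl as the entering ring (a 2.3-fold higher number from compound 1 to compound 4 (0.36 log units; beyond the scatter); a 2.7-fold higher number from compound 3 to compound 4 (0.43 log units; beyond the scatter)). This position is therefore not wholly indifferent to which small aromatic ring it carries, although the step to the other five-membered ring stays within the scatter (a 1.4-fold higher number from compound 2 to compound 4 (0.15 log units; within the scatter)), so compound 2 and compound 4 cannot be put in order. Nothing given here explains why the thiazole ring differs from the six-membered rings of compound 1 and compound 3.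

Still open, on these data alone, is how a plain phenyl ring, with no hetero atoms, would compare at this position. A simple methyl group or a short alkyl chain on the same nitrogen would show whether any aromatic ring is needed there at all.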